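Methyl on the Ring Amine: Compound 1 to Compound 4

The compounds below may be only part of what the source reports. "The series", "measured", "known", "first", "only" and "open" are said of these compounds alone.

The measured compounds and their values:
compound 1, `CCn1cc(-c2nc3ccccc3[nH]2)c(=O)c2cc(F)c(N3CCNCC3)cc21`: 800 nM
compound 2, `CCn1cc(-c2nc3ccccc3[nH]2)c(=O)c2cc(F)c(N3CCNCC3)nc21`: 4800 nM
compound 3, `CCn1cc(-c2nc3ccccc3[nH]2)c(=O)c2cc(F)c(N3CCNC(C)C3)c(F)c21`: 11600 nM

In a functional assay on A2780 cells (Homo sapiens) for cytotoxicity, read by MTT assay, with a stated time of 48 h (a higher number here means a weaker inhibitor, a lower number a stronger inhibitor), compound 1 gives 800 nM, the lowest of the three numbers. The nearest number belongs to compound 2, whose 4800 nM stands beyond the scatter above compound 1. The furthest belongs to compound 3, whose 11600 nM stands further still beyond the scatter. Neither compound 2 nor compound 3 differs from compound 1 in a single place, so their values are noted without a step being drawn between them and compound 1.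

Compound 4, `CCn1cc(-c2nc3ccccc3[nH]2)c(=O)c2cc(F)c(N3CCN(C)CC3)cc21`, differs from compound 1 in one place only: methyl in place of hydrogen on an amine nitrogen in a ring. Read one bond further out, the change is piperazin-1-yl to 4-methylpiperazin-1-yl. Among the measured compounds shown here, nothing among the measured compounds shows what this change does, since no pair among them differs in this way.

On that basis no step beyond the scatter is expected in this assay for compound 4; the value is estimated near that of compound 1, with the step of a 1.3-fold higher number from compound 1 to compound 4 (0.10 log units; within the scatter) expected to fall within the usual scatter. Compound 4 is therefore expected at 1000 nM, with a range from 300 nM to 3500 nM.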

Compound 4, half-maximal inhibitory concentration: > 5010000 nM
Compound 4: a limit, no number; the forecaster's own chance of this, stated with the estimate: 5%; middle value at least 5000-fold (3.69 log units) away from the limit.
By their numbers in this assay, from the lowest: compound 1; then compound 2; then compound 3. At a limit, above all of these: compound 4.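

In this assay compound 4 gives > 5010000 nM, which is a limit and not a number. Among the compounds shown here, the earlier compounds held no pair differing in one place, so this is the first step that can be read at the amine nitrogen of the piperazin-1-yl ring: methyl in place of hydrogen there gives an at least 6200-fold higher number from compound 1 to compound 4 (3.79 log units; beyond the scatter), which shows that on the core of compound 1 this position does not tolerate even this small change without a large loss in this assay. The step is read from a limit: the limit of > 5010000 nM in this assay, at which 1 of the 4 values shown sits.

The compounds shown leave open whether an ethyl group, a longer chain, an acetyl group or a hydroxyethyl group on the same amine nitrogen would behave as methyl does, and so whether the step belongs to methyl itself or to any group placed there. They also leave open whether the same change would give a step of this size on the cores of compound 2 and compound 3, and they offer no measured property that would explain the step.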